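Swapping 4-Fluorophenyl for Pyridin-2-yl on a Ring Nitrogen

The source may report more compounds than this note shows. Statements on the series, on what has been measured and on what is new or still open speak of the compounds shown alone.

In a functional assay on C-33-A cells (Homo sapiens) for antiproliferative activity, read by MTT assay (a lower number here means a stronger inhibitor, a higher number a weaker inhibitor), compound 1 `Fc1ccc(N2CCN(c3nc(-n4ccc5ccccc54)c4ccccc4n3)CC2)cc1` gives 50 ug/mL and stands level with compound 2 `COc1cc(OC)c(-c2nc(N3CCNCC3)nc3ccccc23)c(OC)c1` which gives 50 ug/mL with the two values inside the usual scatter of repeat measurements. Compound 3 `c1ccc(N2CCN(c3nc(-n4ccc5ccccc54)c4ccccc4n3)CC2)nc1` keeps the core of compound 1 but carries pyridin-2-yl in place of 4-fluorophenyl on an amine nitrogen in a ring and has not yet been tested. Among the compounds with values here, no measured pair here differs in one place only, so the data offer no direct guide to the size of this change in this assay and no step beyond the scatter is expected in either direction. The expectation rests on compound 1 at 50 ug/mL as its starting point. The estimated change is a 1.1-fold lower number from compound 1 to compound 3 (0.05 log units; within the scatter) and it remains small. The expected value for compound 3 is 45 ug/mL with an estimated range from 18 ug/mL to 100 ug/mL until the measurement arrives.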

Compound 3, half-maximal inhibitory concentration: 50 ug/mL
For compound 3 the middle estimate is 1.1-fold (0.05 log units) below the measured one, and the stated range covers the measured number.
By their numbers in this assay, from the lowest: compounds 1, 2 and 3 (each within the scatter of the next).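

In this assay, within the data shown here, pyridin-2-yl in place of 4-fluorophenyl on an amine nitrogen in a ring gives no change at the digits printed from compound 1 to compound 3 (within the scatter), and this is the first pair here that differs in one place only. At this position, then, the six-membered aromatic ring of carbon only and the six-membered aromatic ring with one hetero atom read alike, even though the incoming group brings a hydrogen-bond acceptor that the outgoing group lacks. No measured information is at hand to explain this result.

A single swap between two aromatic rings says little about how other groups would behave on this nitrogen. From the compounds shown here alone, whether a benzyl group, a short alkyl chain or a chain ending in a carboxylic acid would move the number beyond the scatter remains open.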